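Compound 3 to compound 4: amino in place of hydroxy

The source may hold more compounds than are shown below. What is called first, only, known or untested is meant among the compounds shown, and "the series" means these compounds.

- compound 1 `COc1cccc(-c2ccc(O)cc2)c1`: 24 ug/mL
- compound 2 `COc1ccc(-c2ccccc2)cc1OC`: 41 ug/mL
- compound 3 `COc1ccc(-c2ccc(O)cc2)cc1OC`: 26 ug/mL

All three values come from a functional assay on HT-29 cells (Homo sapiens) for cytotoxicity, read by MTT assay, with a stated time of 3 days (a lower number here means a stronger inhibitor, a higher number a weaker inhibitor), and span a narrow range. Compound 3, at 26 ug/mL, lies within the scatter of both other compounds, so the three cannot be ranked.

The next compound, compound 4 `COc1ccc(-c2ccc(N)cc2)cc1OC`, has not been measured. It carries amino in place of hydroxy on an aromatic carbon and is otherwise unchanged.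

For the measured compounds named here, two measured steps bear on this change, though only indirectly. Methoxy in place of hydrogen on an aromatic carbon gave a 1.1-fold higher number from compound 1 to compound 3 (0.03 log units; within the scatter), and hydroxy in place of hydrogen on an aromatic carbon gave a 1.6-fold lower number from compound 2 to compound 3 (0.20 log units; within the scatter). Going by the values given here, neither step involves amino, and no measured pair exchanges one group for the other, so the direction cannot be read from the data. The second step matters more, since it shows how little the hydroxy itself moved the number when it was added.

No shift beyond the scatter is therefore expected, and the expected step is a 1.1-fold lower number from compound 3 to compound 4 (0.05 log units; within the scatter) in this assay. Compound 4 is estimated at 23 ug/mL, with an expected range from 10 ug/mL to 50 ug/mL for the measurement.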

Compound 4, half-maximal inhibitory concentration: 2 ug/mL
Compound 4: middle estimate off by 12-fold (1.06 log units), on the high side, and the stated range ends above it.
By their numbers in this assay, from the lowest: compound 4; then compounds 1, 3 and 2 (each within the scatter of the next).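

In this assay the aromatic carbon para to a large group proves sensitive to which group it carries: amino in place of hydroxy gave a 13-fold lower number from compound 3 to compound 4 (1.11 log units; beyond the scatter) even though the two groups match in heavy-atom count, hydrogen-bond donor and acceptor counts, and lack of net charge. Amino in place of hydrogen on the same carbon gave a 21-fold lower number from compound 2 to compound 4 (1.31 log units; beyond the scatter) whereas hydroxy in place of hydrogen gave a 1.6-fold lower number from compound 2 to compound 3 (0.20 log units; within the scatter) and so filling this carbon does not by itself lower the number; in these compounds, only amino does. No available evidence accounts for the difference between amino and hydroxy at this carbon.

Still open, on these data alone, is whether the step depends on the unsubstituted amino group or would carry over to methylamino, dimethylamino or acetamido at the same carbon, and how a carboxylic acid would read there. Also open is whether amino in place of hydroxy would give a step of similar size on the core of compound 1, since the step is shown here on one core only.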